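From fluoro to nitro in a three-compound series

The compounds below may be only part of what the source reports. "The series", "measured", "known", "first", "only" and "open" are said of these compounds alone.

Measured so far in a functional assay on MCF7 cells (Homo sapiens) for inhibition, read by MTT assay, with a stated time of 48 h; on this read-out higher numbers stand for weaker inhibition and lower numbers for stronger inhibition:
compound 1 `O=C(CC(c1ccccc1)C(C(=O)Nc1ccccn1)C(=O)Nc1ccccn1)c1ccccc1` gives "not active" (no number reported)
compound 2 `O=C(CC(c1ccc(F)cc1)C(C(=O)Nc1ccccn1)C(=O)Nc1ccccn1)c1ccccc1` gives 20900 nM
compound 3 `O=C(CC(c1ccc(F)cc1)C(C(=O)Nc1ccccn1)C(=O)Nc1ccccn1)c1ccc(F)cc1` gives 23300 nM

Only compound 2 and compound 3 carry numbers in this assay, and these two lie within the scatter of each other. Compound 1 has no number to compare. The next compound to be tested is compound 4 `O=C(CC(c1ccc([N+](=O)[O-])cc1)C(C(=O)Nc1ccccn1)C(=O)Nc1ccccn1)c1ccccc1`, which has nitro in place of fluoro on an aromatic carbon of compound 2. The difference is nitro in place of fluoro on an aromatic carbon and the same change reads 4-fluorophenyl to 4-nitrophenyl.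

Among the compounds with values here, one measured step bears on this change, and only loosely. Within the data shown here, it is a 1.1-fold higher number from compound 2 to compound 3 (0.05 log units; within the scatter) and it concerns fluoro in place of hydrogen, so no measured step involves nitro. Going by these compounds, on this slim evidence, no shift beyond the scatter is expected, and the direction stays open. The expected step is a 1.1-fold lower number from compound 2 to compound 4 (0.04 log units; within the scatter) in this estimate. For compound 4 the estimated value is 19000 nM with an expected range from 6500 nM to 55000 nM in the coming measurement.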

Compound 4, half-maximal inhibitory concentration: "not active" (no number reported)
Compound 4: no number reported, and the estimate cannot be compared.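

In this assay compound 4 gives "not active" (no number reported) and compound 2 gives 20900 nM so no step can be read between them. The compounds shown leave open how far 4-nitrophenyl in place of 4-fluorophenyl moves the read-out. Nothing available here accounts for this result.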